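The source may hold more compounds than are shown below. What is called first, only, known or untested is meant among the compounds shown, and "the series" means these compounds.

Compound 3 `O=C(Nc1cccc(F)c1)O/N=C(\C1CCCCC1)C(Cc1cccs1)C1CCCCC1` is the starting point of this account. In a functional assay on E17 cells for antagonist activity at metabotropic glutamate receptor 5 (Rattus norvegicus), read by fluorescence and calcium flux (on this read-out higher numbers stand for weaker inhibition and lower numbers for stronger inhibition), compound 3 gives 46 nM, the lowest of the two single numbers gathered there; the nearest neighbour is compound 2 `O=C(Nc1cccc(Cl)c1)O/N=C(\C1CCCCC1)C(Cc1cc[nH]c1)C1CCCCC1`, which in this assay gives 194 nM, a gap beyond the scatter. Compound 1 `O=C(Nc1cccc(Cl)c1)O/N=C(\C1CCCCC1)C(Cn1ccnc1)C1CCCCC1` is also part of the set, and in this assay compound 1 gives 117 nM; 76 nM (2 entries); the two entries for compound 1 the several entries of compound 1 in this assay, 117 nM; 76 nM (2 entries) show how far repeated measurements of one compound can drift.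

Compound 4 `COc1cccc(NC(=O)O/N=C(\C2CCCCC2)C(Cc2cccs2)C2CCCCC2)c1` has not yet been measured. It differs from compound 3 in one place: methoxy in place of fluoro on an aromatic carbon. For the measured compounds named here, no measured pair in this set shows that same change, so the size of the step is not fixed by any comparison here. The author expects a step from compound 3 to compound 4 of a 1.6-fold higher number from compound 3 to compound 4 (0.21 log units; within the scatter), toward a somewhat higher number, though one that may well stay within the scatter. In this assay compound 4 is estimated to give 75 nM, with a range from 25 nM to 220 nM.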

Compound 4, half-maximal inhibitory concentration: 181 nM
Estimate against measurement, compound 4: 2.4-fold (0.38 log units) below; measured number inside the range.
By their numbers in this assay, from the lowest: compound 3; then compounds 4 and 2 (each within the scatter of the next).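

In this assay, the substituent at this place on the six-membered aromatic ring is not indifferent: methoxy in place of fluoro brings a 3.9-fold higher number from compound 3 to compound 4 (0.59 log units; beyond the scatter). For the compounds shown here, this is the first change in the set that can be read at a single place, since the earlier compounds differ from one another in more than one. The step is also wider than the drift between repeated measurements of one compound: the several entries of compound 1 in this assay, 117 nM; 76 nM (2 entries)

Going by these compounds, what remains open is whether the step follows from losing fluoro or from gaining methoxy, as a single pair cannot separate the two. The compounds shown also do not tell how a methyl, an amine or a nitrile at the same place would read on the core of compound 3, or whether the same change would give a step of similar size on the core of compound 1.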